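The source may report more compounds than this note shows. Statements on the series, on what has been measured and on what is new or still open speak of the compounds shown alone.

Compound 2 `Cc1cccc(S(=O)(=O)Nc2ccc3oc(-c4ccccc4)nc3c2)c1` is one of three compounds tested in an assay on cells for inhibition of HSP60/HSP10 (Homo sapiens), with a stated time of 60 min; on this read-out higher numbers stand for weaker inhibition and lower numbers for stronger inhibition. In this assay compound 2 gives > 100000 nM, which is a limit of the assay rather than a measured number. Compound 1 `O=S(=O)(Nc1ccc2oc(-c3ccccc3)nc2c1)c1cccc(C(F)(F)F)c1` gives > 100000 nM in this assay, again a limit. Compound 3 `O=S(=O)(Nc1ccc(-c2nc3ccccc3o2)cc1)c1ccccc1Cl` differs from compound 2 in several places. In this assay compound 3 gives > 100000 nM, also a limit. Going by the values given here, the only step between measured compounds that differ in a single place, a step that the two limits leave unreadable from compound 1 to compound 2, therefore tells nothing about size. All that the measured compounds show is the limit of > 100000 nM in this assay, at which 3 of the 3 values shown sit.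

Compound 4 `O=S(=O)(Nc1ccc2oc(-c3ccccc3)nc2c1)c1ccccc1F` is the compound not yet measured. It differs from compound 2 by 2-fluorophenyl in place of 3-methylphenyl on a sulfonyl sulfur. Among the compounds with values here, no measured step bears on this change, and no expectation of a step beyond the scatter in this assay can be drawn from the numbers; the most that can be said is that every value so far is a limit. Compound 4 is therefore expected to sit near that limit. The expected step is a number no higher from compound 2 to compound 4 (the limit leaves the size open). The estimated value of compound 4 in this assay is 100000 nM, with a range from 30000 nM to 300000 nM.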

Compound 4, half-maximal inhibitory concentration: > 100000 nM
Compound 4: only a limit was reported; the forecaster's own chance of this, stated with the estimate: 85%; the middle value sits exactly at the limit.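

Compound 2 and compound 4 are both reported only as limits of the assay, not as measured numbers, so no step between them can be read, and the picture stays the same: the limit of > 100000 nM in this assay, at which 4 of the 4 values shown sit.

The compounds shown leave open how strongly any of them inhibits, and whether 2-fluorophenyl in place of 3-methylphenyl on a sulfonyl sulfur changes inhibition at all.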